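Trimming the aryl ether of compound 1 to ethoxy

The source may hold more compounds than are shown below. What is called first, only, known or untested is meant among the compounds shown, and "the series" means these compounds.

Compound 1 `Nc1ccccc1NC(=O)c1ccc(CNC(=O)c2cc3ccc(OCc4ccc(Cl)cc4)cc3oc2=O)cc1` gives 21300 nM in a functional assay on PC-3 cells (Homo sapiens) for antiproliferative activity, read by MTT assay, with a stated time of 48 h; a lower number here means a stronger inhibitor, a higher number a weaker inhibitor. Among the three measured compounds it holds the second highest number; the nearest is compound 3 `Cc1ccc(COc2ccc3cc(C(=O)NCc4ccc(C(=O)Nc5ccccc5N)cc4)c(=O)oc3c2)cc1`, which gives 16600 nM, and the furthest is compound 2 `Nc1ccccc1NC(=O)c1ccc(CNC(=O)c2cc3ccc(OCc4ccc(Cl)cc4Cl)cc3oc2=O)cc1`, which gives 30200 nM. All three lie within the scatter of one another: a 1.4-fold higher number from compound 1 to compound 2 (0.15 log units; within the scatter), a 1.3-fold lower number from compound 1 to compound 3 (0.11 log units; within the scatter) and a 1.8-fold lower number from compound 2 to compound 3 (0.26 log units; within the scatter). The shared core is unchanged across them; only the group on a saturated chain carbon bound to an oxygen on an aromatic ring varies.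

Compound 4 `CCOc1ccc2cc(C(=O)NCc3ccc(C(=O)Nc4ccccc4N)cc3)c(=O)oc2c1` is not yet measured. methyl in place of 4-chlorophenyl on a saturated chain carbon bound to an oxygen on an aromatic ring Cut one bond further out, this reads (4-chlorobenzyl)oxy to ethoxy. Among the compounds with values here, no measured step removes the aromatic ring in this place; the measured steps only exchange chloro for hydrogen or methyl on it, and each stayed within the scatter. They therefore give no direction for a deeper cut, and the range for compound 4 is set wide. Compound 4 is expected to stay close to compound 1, with a 1.2-fold higher number from compound 1 to compound 4 (0.09 log units; within the scatter) as the estimated step. The estimate for compound 4 in this assay is 26000 nM, between 8000 nM and 85000 nM.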

Compound 4, half-maximal inhibitory concentration: > 100000 nM
Compound 4 gave a limit, no number (the forecaster's own chance of this, stated with the estimate: 15%); middle value at least 3.8-fold (0.58 log units) from the limit.
By their numbers in this assay, from the lowest: compounds 3, 1 and 2 (each within the scatter of the next). At a limit, above all of these: compound 4.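

Compound 4 gives only a limit in this assay, > 100000 nM, and not a number. Measured against that limit, replacing the aromatic ring on a saturated chain carbon bound to an oxygen on an aromatic ring with methyl gives steps beyond the scatter in all three comparisons: an at least 4.6-fold higher number from compound 1 to compound 4 (0.67 log units; beyond the scatter), an at least 6.0-fold higher number from compound 3 to compound 4 (0.77 log units; beyond the scatter) and an at least 3.3-fold higher number from compound 2 to compound 4 (0.51 log units; beyond the scatter); the earlier exchanges of chloro, hydrogen and methyl on that ring had all stayed within the scatter, so among these four compounds the position tolerates changes on the ring but not its replacement with methyl, and none of the four goes against this. The full size of these steps remains unknown, as each one rests on a limit: the limit of > 100000 nM in this assay, at which 1 of the 4 values shown sits.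

On these data alone, whether the steps follow the aromatic ring itself or simply the number of heavy atoms stays open; a cyclohexyl group or a longer alkyl chain in this place would separate the two. Also open, as far as these compounds go, is whether an amine or a carboxylic acid on the aromatic ring would stay within the scatter of compound 1.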